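From 4-bromophenyl to thiophen-3-yl on a shared core

The source may report more compounds than this note shows. Statements on the series, on what has been measured and on what is new or still open speak of the compounds shown alone.

In an ADME assay on L6 cells (Rattus norvegicus) for cytotoxicity, read by resazurin assay, with a stated time of 72 h (on this read-out lower numbers stand for stronger inhibition and higher numbers for weaker inhibition), compound 1 (`OC(c1ccc(Cl)cc1)(c1ccc(Br)cc1)c1cccnc1`) gives 57000 nM and stands level with compound 2 (`OC(c1ccc(Cl)cc1)(c1ccc(C(F)(F)F)cc1)c1cccnc1`) at 56400 nM and compound 3 (`CC(C)Oc1ccc(C(O)(c2ccc(Cl)cc2)c2cccnc2)cc1`) at 56600 nM with all three within the scatter of one another. Compound 4 (`OC(c1ccc(Cl)cc1)(c1cccnc1)c1ccsc1`) has not yet been measured. It carries thiophen-3-yl in place of 4-bromophenyl on a saturated chain carbon bound to two aromatic carbons and an oxygen on a saturated carbon. Within the data shown here, two measured steps bear on this, though neither removes the whole 4-bromophenyl: a 1.0-fold lower number from compound 1 to compound 2 (0.00 log units; within the scatter) for trifluoromethyl in place of bromo and a 1.0-fold lower number from compound 1 to compound 3 (0.00 log units; within the scatter) for isopropoxy in place of bromo, both within the scatter. Among the measured compounds shown here, on the strength of those two steps from compound 1 no shift beyond the scatter is expected in this assay in either direction, although no measured compound carries thiophen-3-yl. The expected step is a 1.0-fold lower number from compound 1 to compound 4 (0.02 log units; within the scatter) and so stays within the scatter. For compound 4 the estimate is 55000 nM with 25000 nM to 110000 nM as its expected range.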

Compound 4, half-maximal inhibitory concentration: > 100000 nM
Compound 4 ended at the assay's limit (the forecaster's own chance of this, stated with the estimate: 15%); middle value at least 1.8-fold (0.25 log units) away from the limit.
By their numbers in this assay, from the lowest: compounds 2, 3 and 1 (each within the scatter of the next). At a limit, above all of these: compound 4.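

The earlier compounds shown here changed only the group carried on the aromatic ring and kept that ring in place, whereas this change replaces the whole 4-bromophenyl with thiophen-3-yl on the saturated chain carbon, and it gives an at least 1.7-fold higher number from compound 1 to compound 4 (0.24 log units; that floor lies within the scatter). That floor does not by itself establish a shift in this assay, but the ring swap brought no stronger inhibition than the bromo, trifluoromethyl and isopropoxy compounds show. For compound 4 the value > 100000 nM is a limit of the assay and not a number, and it is the only such value among the compounds shown: the limit of > 100000 nM in this assay, at which 1 of the 4 values shown sits.

From the compounds shown here alone, how far compound 4 truly lies from compound 1 stays open. So does whether an amine or a carboxylic acid on the ring at this position would move the number at all.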